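The source may report more compounds than this note shows. Statements on the series, on what has been measured and on what is new or still open speak of the compounds shown alone.

Compound 2 `N[C@@H](COP(=O)(O)OCCCOC(=O)CCc1ccccc1OCc1cccc(Oc2ccc(Cl)c(Cl)c2)c1)C(=O)O` gives 0.71 in an assay on cells for activation of probable G-protein coupled receptor 34 (Mus musculus), with a stated time of 1 h (a lower number here means a smaller maximal response, a higher number a larger maximal response), the higher of the two values recorded; the nearest, compound 1 `N[C@@H](COP(=O)(O)OCCCOC(=O)CCc1ccccc1OCc1cccc(Cc2ccccc2)c1)C(=O)O`, gives 0.077. Within the data shown here, the one measured step, a number 0.63 higher from compound 1 to compound 2 (beyond the scatter), replaced a benzyl with a 3,4-dichlorophenoxy group. Compound 3 `N[C@@H](COP(=O)(O)OCCCOC(=O)CCc1ccccc1OCc1cccc(Oc2ccc(F)cc2)c1)C(=O)O` is the next compound; the change is 4-fluorophenyl in place of 3,4-dichlorophenyl on an oxygen on an aromatic ring. Among the measured compounds shown here, the phenoxy link remains, so compound 3 is expected to stay well above compound 1, but no measured step bears directly on swapping the chlorines for a fluorine, so a moderate fall is expected, a number 0.21 lower from compound 2 to compound 3 (beyond the scatter). Compound 3 is estimated at 0.5, between 0.25 and 0.75.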

Compound 3, intrinsic activity: the largest response reached, as a fraction of the reference agonist's: 0.66
Beside the measured number, compound 3's estimate is 0.16 below it; the measured number falls inside the stated range.
By their numbers in this assay, from the lowest: compound 1; then compounds 3 and 2 (each within the scatter of the next).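

With 4-fluorophenyl in place of 3,4-dichlorophenyl on the oxygen, this assay shows a number 0.050 lower from compound 2 to compound 3 (within the scatter) and so does not separate the two groups. A second phenoxy compound also stands clear of the benzyl compound, with a number 0.58 higher from compound 1 to compound 3 (beyond the scatter) as the step, so among these compounds the large maximal response does not depend on the two chlorines. Nothing measured here explains this result.

As far as these compounds go, it remains open whether the oxygen link or the halogen on the ring accounts for the gap to compound 1. An unsubstituted phenoxy group would separate the two, and a methoxy group would test whether the ring is needed at all.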